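Clearance across three amides, and a fourth to come

This account rests on a few compounds, and the source may have more. Where it says the series, first, only, none or still open, it means among the compounds named here.

Three amides sharing one core have been read in an in vitro ADME assay on microsomes from liver (Homo sapiens) for pharmacokinetics, read by LC-MS, with a stated time of 10 min, tested at 1 uM; on this read-out higher numbers stand for fast clearance and lower numbers for slow clearance. In that assay compound 1 `CN1C[C@H](C(=O)Nc2ccc(C3CC3)cc2)[C@@H](c2ccc(/C=C/C(=O)Nc3ccccc3N)cc2)C1` gives 12 mL/min/kg, compound 2 `Cc1cc(NC(=O)[C@H]2CN(C)C[C@@H]2c2ccc(/C=C/C(=O)Nc3ccccc3N)cc2)ccc1Cl` gives 15 mL/min/kg and compound 3 `CN1C[C@H](C(=O)Nc2ccc(F)cc2F)[C@@H](c2ccc(/C=C/C(=O)Nc3ccccc3N)cc2)C1` gives 12 mL/min/kg. Compound 3 thus stands level with compound 1 at the digits shown, and all three values lie within the scatter of one another.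

The next compound, compound 4 `CN1C[C@H](C(=O)Nc2ccc(Cl)cn2)[C@@H](c2ccc(/C=C/C(=O)Nc3ccccc3N)cc2)C1`, differs from compound 3 in one place: 5-chloropyridin-2-yl in place of 2,4-difluorophenyl on an amide-type nitrogen. In words, it has 5-chloropyridin-2-yl in place of 2,4-difluorophenyl on an amide-type nitrogen.

Three measured exchanges at this same place bear on the change: a 1.3-fold higher number from compound 1 to compound 2 (0.10 log units; within the scatter), a 1.3-fold lower number from compound 2 to compound 3 (0.10 log units; within the scatter) and no change at the digits printed from compound 1 to compound 3 (within the scatter). All of them stay within the scatter. Among the measured compounds shown here, none of them brings in a ring with a hetero atom, however, so the data offer no direct precedent for the entering group, and the range has to stay wide.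

As far as these compounds go, on this evidence, no move beyond the scatter is expected in this assay, and the direction remains open. The estimated step is a 1.2-fold higher number from compound 3 to compound 4 (0.07 log units; within the scatter). For compound 4 the expected value is 14 mL/min/kg, with an estimated range from 8 mL/min/kg to 26 mL/min/kg.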

Compound 4, clearance: 13 mL/min/kg
Compound 4: the middle estimate sits 1.1-fold (0.03 log units) above what was measured; measured number inside the range.
By their numbers in this assay, from the lowest: compounds 1, 3, 4 and 2 (each within the scatter of the next).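

With 5-chloropyridin-2-yl, a ring with a hetero atom and a hydrogen-bond acceptor now stands on the amide-type nitrogen for the first time among these compounds, and in this assay the exchange for 2,4-difluorophenyl gives a 1.1-fold higher number from compound 3 to compound 4 (0.03 log units; within the scatter). The comparisons with the other two amides read the same way, with a 1.2-fold lower number from compound 2 to compound 4 (0.06 log units; within the scatter) and a 1.1-fold higher number from compound 1 to compound 4 (0.03 log units; within the scatter), so this position has now tolerated a ring with a hetero atom as well as rings of carbon only, with every step among the four compounds staying within the scatter. Nothing available here accounts for this result.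

As far as these compounds go, all four groups at this place are six-membered aromatic rings, so it remains open whether a saturated ring amine such as piperidine, a carboxylic acid or a longer alkyl chain on this nitrogen would stay within the same band in this assay. The compounds shown also leave open what a ring with a second nitrogen, such as pyrimidine, would do at this position.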